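Swapping a hexyl for a carboxypropylcarbonyl on the amine

The compounds below may be only part of what the source reports. "The series", "measured", "known", "first", "only" and "open" are said of these compounds alone.

Measured so far:
compound 1 `CCCCCCCCCCCCCCC(N)CO` — 7000 nM
compound 2 `CCCCCCCCCCCCCCC(CO)NCCCCCC` — 6000 nM
compound 3 `CCCCCCCCCCCCCCC(COCc1ccccc1)NCC(=O)O` — 3000 nM

All three numbers come from a functional assay on Jurkat cells (Homo sapiens) for inhibition; on this read-out higher numbers stand for weaker inhibition and lower numbers for stronger inhibition. Compound 2 stands second highest of the three: compound 1 is nearest, with a number that is higher but within the scatter, and compound 3 is furthest, with a number that is lower but still within the scatter. Within the data shown here, on this footing no compound can be called stronger or weaker than another.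

Compound 4 `CCCCCCCCCCCCCCC(CO)NC(=O)CCCC(=O)O` has not yet been measured. It differs from compound 2 in one place: (3-carboxypropyl)carbonyl in place of hexyl on an amine nitrogen.

Among the measured compounds shown here, only one measured step is known between compounds that differ in one place, a 1.2-fold lower number from compound 1 to compound 2 (0.07 log units; within the scatter), and it changes the same amine nitrogen. Compound 3, which also carries a carboxylic acid, gives 3000 nM, but it differs from compound 2 in two places, so no single step can be read from it. Because a 1.2-fold lower number from compound 1 to compound 2 (0.07 log units; within the scatter) stayed within the scatter, no step beyond the scatter is expected in this assay for the change to compound 4 either. The estimate for compound 4 is therefore 6000 nM, with a range from 2000 nM to 18000 nM, which means an expected step of no change at the digits printed from compound 2 to compound 4 (within the scatter).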

Compound 4, half-maximal inhibitory concentration: 24000 nM
Compound 4: the middle estimate sits 4.0-fold (0.60 log units) below what was measured; the whole stated range lies below it.
By their numbers in this assay, from the lowest: compounds 3, 2 and 1 (each within the scatter of the next, the first and the last beyond it); then compound 4.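

Among these compounds, this is the first change on the amine nitrogen that moves the number beyond the scatter. In this assay, (3-carboxypropyl)carbonyl in place of hexyl gives a 4.0-fold higher number from compound 2 to compound 4 (0.60 log units; beyond the scatter), and the same group in place of hydrogen gives a 3.4-fold higher number from compound 1 to compound 4 (0.54 log units; beyond the scatter), both modest steps toward weaker inhibition. The nitrogen is therefore not indifferent to what it carries, since hydrogen and hexyl stay within the scatter of each other while this group stands apart from both, although nothing measured here bears on the reason for that difference.

The entering group brings a carbonyl on the nitrogen and a carboxylic acid in a single change, so the compounds shown cannot tell which of the two goes with the step. A hexanoyl group, which has the carbonyl without the acid, or the methyl ester of the same carboxypropylcarbonyl group, would help to separate the two parts, and an amine in place of the acid would show whether other groups at this spot give a similar step.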